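The source may report more compounds than this note shows. Statements on the series, on what has been measured and on what is new or still open speak of the compounds shown alone.

Measured so far:
- compound 1 `CNC(=O)c1cc(Oc2ccc(NC(=O)c3nn(-c4ccc(Br)cc4F)c(=O)cc3C)cc2F)ccn1`, which in a functional assay on MCF7 cells (Homo sapiens) for cytotoxicity, read by MTT assay, with a stated time of 72 h (on this read-out lower numbers stand for stronger inhibition and higher numbers for weaker inhibition), gives 9360 nM
- compound 2 `CNC(=O)c1cc(Oc2ccc(NC(=O)c3nn(-c4ccccc4F)c(=O)cc3C)cc2F)ccn1`, for which this assay reports only a limit, > 40000 nM
- compound 3 `O=C(Nc1ccc(Oc2ncnc3ccsc23)c(F)c1)c1nn(-c2ccc(Br)cc2)ccc1=O`, which gives 9620 nM in this assay

Compounds 1 and 2 share one core and differ in a single place: hydrogen in place of bromo on an aromatic carbon. That change made a step of an at least 4.2-fold higher number from compound 1 to compound 2 (0.63 log units; beyond the scatter), and the step runs into (the limit of > 40000 nM in this assay, at which 1 of the 3 values shown sits), so its true size is not known, only that it is at least this large. Compound 3 is built on a different core; the difference between the two cores is not broken down here. Its value sits beside that of compound 1, within the usual scatter.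

Compound 4 `O=C(Nc1ccc(Oc2ncnc3ccsc23)c(F)c1)c1nn(-c2ccccc2)ccc1=O` is compound 3 with the same kind of change: hydrogen in place of bromo on an aromatic carbon. The surroundings are not identical. In compound 1 the bromo sits meta to a fluoro group and para to a large group, while in compound 3 it sits only para to a large group. Given that compound 1 and compound 3 give such close values and that removing the bromo from compound 1 gave an at least 4.2-fold higher number from compound 1 to compound 2 (0.63 log units; beyond the scatter), a loss of the same order is expected here, a 4.7-fold higher number from compound 3 to compound 4 (0.67 log units; beyond the scatter). Compound 4 is therefore estimated at 45000 nM, likely between 20000 nM and 120000 nM, with a fair chance that this assay again reports only a limit.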

Compound 4, half-maximal inhibitory concentration: 12400 nM
For compound 4 the middle estimate is 3.6-fold (0.56 log units) above the measured one, outside the stated range (below it).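

On the core of compound 3, replacing the bromo with hydrogen gives a 1.3-fold higher number from compound 3 to compound 4 (0.11 log units; within the scatter) in this assay, so the 4-bromophenyl to phenyl change does not carry over from the core of compound 1 at the same size. Among the compounds shown here, the two steps are clearly separate, even though they come from the same change: the same change on two cores in this assay, an at least 4.2-fold higher number (0.63 log units; beyond the scatter) from compound 1 to compound 2 and a 1.3-fold higher number (0.11 log units; within the scatter) from compound 3 to compound 4, at least 3.3-fold (0.52 log units) apart, beyond the scatter of two such steps This shows that the result of this change depends on its surroundings, but with only two pairs it does not show which part of those surroundings matters, since the cores differ and the fluoro group on the ring of compound 1 has no counterpart on the ring of compound 3.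

From the compounds shown here alone, the full size of the step on the core of compound 1 stays open, since compound 2 is recorded only as a limit: the limit of > 40000 nM in this assay, at which 1 of the 4 values shown sits. Also open is how other groups would behave in the same place on each core, for example a chloro group, a methoxy group or an amine, and whether any of them would separate the two cores as the bromo does.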